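A Methoxyphenyl Takes the Place of Dimethylphenyl on the Carbonyl

A few compounds are considered here, and "the series" means these few. Any claim that something is new, unique, unknown or untested is made for them only; others in the source may bear on it.

Among the compounds with values here, in a functional assay on A549 cells (Homo sapiens) for antiproliferative activity, read by MTT assay, with a stated time of 24 h (a lower number here means a stronger inhibitor, a higher number a weaker inhibitor), compound 2 `COc1ccc(-c2cc(/C=C/C(=O)c3ccc(C)c(C)c3)nc3cc(-c4ccccc4)nn23)cc1OC` gives 9300 nM, the highest of the two numbers measured so far, while compound 1 `COc1ccc(-c2cc(/C=C/C(=O)c3cc(OC)c(OC)c(OC)c3)nc3cc(-c4ccccc4)nn23)cc1OC` gives 7200 nM. Within the data shown here, the only step between measured compounds, a 1.3-fold higher number from compound 1 to compound 2 (0.11 log units; within the scatter), stays within the scatter. Compound 3 `COc1ccc(C(=O)/C=C/c2cc(-c3ccc(OC)c(OC)c3)n3nc(-c4ccccc4)cc3n2)cc1` differs from compound 2 by 4-methoxyphenyl in place of 3,4-dimethylphenyl on a carbonyl carbon. That one measured step exchanged a group at the same carbonyl carbon and barely moved the number, so no shift beyond the scatter is expected here either. Compound 3 is estimated at 8000 nM, with a range from 3000 nM to 25000 nM. This expectation amounts to a 1.2-fold lower number from compound 2 to compound 3 (0.07 log units; within the scatter).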

Compound 3, half-maximal inhibitory concentration: 11900 nM
Estimate against measurement, compound 3: 1.5-fold (0.17 log units) below, within the range that was stated.
By their numbers in this assay, from the lowest: compounds 1, 2 and 3 (each within the scatter of the next).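

In this assay, replacing 3,4-dimethylphenyl with 4-methoxyphenyl gives a 1.3-fold higher number from compound 2 to compound 3 (0.11 log units; within the scatter), and replacing 3,4,5-trimethoxyphenyl with 4-methoxyphenyl gives a 1.7-fold higher number from compound 1 to compound 3 (0.22 log units; within the scatter). On this carbonyl carbon, then, all three phenyl groups now give numbers within the scatter of one another, including the pair of groups not compared before. Nothing available explains why these groups read alike. As far as these compounds go, all three are substituted phenyl rings, so it remains open whether an amine or a carboxylic acid on that ring, or a pyridine in its place, would move the number beyond the scatter.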